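This account rests on a few compounds, and the source may have more. Where it says the series, first, only, none or still open, it means among the compounds named here.

Measured compounds in a functional assay on A549 cells (Homo sapiens) for inhibition, read by MTT assay, with a stated time of 72 h; on this read-out lower numbers stand for stronger inhibition and higher numbers for weaker inhibition:
- compound 1 `COc1cc2c(Oc3ccc(NC(=O)c4nn(-c5ccccc5C)c(=O)cc4C)cc3F)ccnc2cc1OCCCN1CCC(C)CC1`: 1460 nM
- compound 2 `COc1cc2c(Oc3ccc(NC(=O)c4nn(-c5ccccc5OC(F)(F)F)c(=O)cc4C)cc3F)ccnc2cc1OCCCN1CCC(C)CC1`: 90 nM
- compound 3 `COc1cc2c(Oc3ccc(NC(=O)c4nn(-c5cccc(F)c5)c(=O)cc4C)cc3F)ccnc2cc1OCCCN1CCC(C)CC1`: 250 nM

Compound 3 sits second highest of the three numbers in this assay: a 2.8-fold higher number from compound 2 to compound 3 (0.44 log units; beyond the scatter) separates it from compound 2, and a 5.8-fold lower number from compound 1 to compound 3 (0.77 log units; beyond the scatter) from compound 1. All three compounds share the same core and differ only in the aryl group on the aromatic nitrogen of the six-membered ring with 2 nitrogen.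

Compound 4 `COc1cc2c(Oc3ccc(NC(=O)c4nn(-c5ccc(Cl)cc5)c(=O)cc4C)cc3F)ccnc2cc1OCCCN1CCC(C)CC1` is not yet measured. Its change from compound 3 is 4-chlorophenyl in place of 3-fluorophenyl on an aromatic nitrogen; the new group again sits on the aromatic nitrogen, next to the ring nitrogen.

The measured steps that bear on this position are a 5.8-fold lower number from compound 1 to compound 3 (0.77 log units; beyond the scatter) and a 2.8-fold higher number from compound 2 to compound 3 (0.44 log units; beyond the scatter), both beyond the scatter, together with a 16-fold lower number from compound 1 to compound 2 (1.21 log units; beyond the scatter), which is large. They show that the aryl substituent on this nitrogen moves the number strongly, but none of them replaces a 3-fluorophenyl with a 4-chlorophenyl, so the direction for compound 4 is open. For the measured compounds named here, no step supports a shift beyond the scatter in either direction, and the expectation is therefore a step of about no change at the digits printed from compound 3 to compound 4 (within the scatter), with wide uncertainty.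

Compound 4 is estimated at 250 nM in this assay, within a range of 80 nM to 800 nM.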

Compound 4, half-maximal inhibitory concentration: 210 nM
The estimate for compound 4 lay 1.2-fold (0.08 log units) above the measured number, within the range that was stated.
By their numbers in this assay, from the lowest: compound 2; then compounds 4 and 3 (each within the scatter of the next); then compound 1.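

In this assay, 4-chlorophenyl in place of 3-fluorophenyl on the aromatic nitrogen gives a 1.2-fold lower number from compound 3 to compound 4 (0.08 log units; within the scatter). For the compounds shown here, this is the first step at this position that stays within the scatter, so these two aryl groups cannot be told apart on this read-out, even though they differ in both the halogen and where it sits. Compound 4 also stands clear of the other two compounds, with a 2.3-fold higher number from compound 2 to compound 4 (0.37 log units; beyond the scatter) and a 7.0-fold lower number from compound 1 to compound 4 (0.84 log units; beyond the scatter), so the two halogen-bearing aryl groups both fall between 2-(trifluoromethoxy)phenyl and 2-methylphenyl, and no measurement at hand explains this grouping.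

Substituent and ring place still vary together across all four compounds, so the series cannot say whether the low number of compound 2 follows from the trifluoromethoxy group itself or from where it sits; 4-(trifluoromethoxy)phenyl, 2-fluorophenyl and 2-chlorophenyl would separate the two. On these data alone, how unsubstituted phenyl, or an aryl group carrying an amine or a carboxylic acid, would behave on this nitrogen also remains open.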